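The compounds below may be only part of what the source reports. "The series", "measured", "known", "first", "only" and "open" are said of these compounds alone.

Measured in a functional assay on MGC-803 cells (Homo sapiens) for antiproliferative activity, read by MTT assay, with a stated time of 72 h; on this read-out higher numbers stand for weaker inhibition and lower numbers for stronger inhibition:
- compound 1 `C/C(=N\NC(=O)c1cccc(S(=O)(=O)N2CCOCC2)c1)c1ccccc1O`: 1220 nM
- compound 2 `COc1ccc(/C=N/NC(=O)c2cccc(S(=O)(=O)N3CCOCC3)c2)c(O)c1`: 2070 nM
- compound 3 `CCOc1cccc(/C=N/NC(=O)c2cccc(S(=O)(=O)N3CCOCC3)c2)c1O`: 18000 nM

Compound 3, at 18000 nM, has the highest number of the three. Next is compound 4 `O=C(N/N=C/c1cc(Br)cc(Br)c1O)c1cccc(S(=O)(=O)N2CCOCC2)c1`, with this change: 3,5-dibromo-2-hydroxyphenyl in place of 3-ethoxy-2-hydroxyphenyl on a carbon with a double bond to nitrogen. Among the compounds with values here, the only measured step at this place is an 8.7-fold higher number from compound 2 to compound 3 (0.94 log units; beyond the scatter), a modest one, and it arrives at the same 3-ethoxy-2-hydroxyphenyl group that now leaves. Within the data shown here, no measured compound carries bromine, so the range stays wide. A move towards a lower number in this assay is expected, somewhat smaller than that step. The expected step is a 4.5-fold lower number from compound 3 to compound 4 (0.65 log units; beyond the scatter). Compound 4 is estimated at 4000 nM, with an expected range of 1000 nM to 16000 nM.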

Compound 4, half-maximal inhibitory concentration: 17800 nM
The estimate for compound 4 lay 4.5-fold (0.65 log units) below the measured number; the whole stated range lies below it.
By their numbers in this assay, from the lowest: compounds 1 and 2 (each within the scatter of the next); then compounds 4 and 3 (each within the scatter of the next).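

In this assay, 3,5-dibromo-2-hydroxyphenyl in place of 3-ethoxy-2-hydroxyphenyl on a carbon with a double bond to nitrogen gives a 1.0-fold lower number from compound 3 to compound 4 (0.00 log units; within the scatter), so two different groups read alike at this place. With 2-hydroxy-4-methoxyphenyl as the reference, the change gives an 8.6-fold higher number from compound 2 to compound 4 (0.93 log units; beyond the scatter), so the gap seen earlier is not confined to the ethoxy compound. No measurement at hand explains this result. Still open, as far as these compounds go, is how a single bromine or a dimethylamino group would read at this place.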